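The compounds below may be only part of what the source reports. "The series", "measured", "known", "first", "only" and "open" are said of these compounds alone.

Measured so far in a functional assay on HepG2 cells (Homo sapiens) for inhibition, read by MTT assay, with a stated time of 48 h; a lower number here means a stronger inhibitor, a higher number a weaker inhibitor:
compound 1 `Fc1ccc(/C=N/Nc2nc(-c3ccc(C(F)(F)F)cc3)cs2)cc1F` gives 14500 nM
compound 2 `COc1ccccc1-c1csc(N/N=C/c2ccc(F)c(F)c2)n1` gives > 100000 nM (a limit of the assay, not a number)
compound 3 `Fc1ccc(/C=N/Nc2nc(-c3cccc(Br)c3)cs2)cc1F` gives 16700 nM

Compound 3 lies within the scatter of compound 1, and the only other entry is the limit of compound 2. Compound 4 `Fc1ccc(/C=N/Nc2nc(-c3ccccc3)cs2)cc1F` differs from compound 3 by hydrogen in place of bromo on an aromatic carbon. Among the compounds with values here, one measured step bears on this: an at least 5.9-fold lower number from compound 2 to compound 3 (0.77 log units; beyond the scatter), which starts from a limit and involves a different pair of groups. Compound 1 and compound 3 carry different groups on the phenyl yet sit within the scatter of each other, whereas compound 2 goes against any idea that such changes never matter. The expected change is a 1.3-fold higher number from compound 3 to compound 4 (0.12 log units; within the scatter), not beyond the scatter, with a slight lean to a higher number. For compound 4 the estimated value is 22000 nM, with an expected range of 8000 nM to 60000 nM.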

Compound 4, half-maximal inhibitory concentration: > 100000 nM
Compound 4 ended at the assay's limit (the forecaster's own chance of this, stated with the estimate: 12%); middle value at least 4.5-fold (0.65 log units) from the limit.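

In this assay, hydrogen in place of bromo gives an at least 5.9-fold higher number from compound 3 to compound 4 (0.77 log units; beyond the scatter), and hydrogen in place of trifluoromethyl gives an at least 6.8-fold higher number from compound 1 to compound 4 (0.83 log units; beyond the scatter). A measurable number in this small set therefore goes with a group on the phenyl, although compound 2 goes against any claim that every such group suffices. The value of compound 4 is a limit, as is that of compound 2, and the step between them cannot be read: the limit of > 100000 nM in this assay, at which 2 of the 4 values shown sit.

From the compounds shown here alone, the full size of both readable steps stays open. So does whether an amine or a carboxylic acid on this aromatic carbon would give a measurable number.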